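The source may report more compounds than this note shows. Statements on the series, on what has been measured and on what is new or still open speak of the compounds shown alone.

For the measured compounds named here, in a functional assay on HCT-116 cells (Homo sapiens), read by MTT assay, with a stated time of 72 h (a lower number here means a stronger inhibitor, a higher number a weaker inhibitor), compound 3 `C#Cc1cn([C@@H]2O[C@H](CO)[C@@H](O)[C@H]2O)c2ncnc(SC)c12` gives 90 nM, the lowest number so far. Compound 1 `COc1ncnc2c1c(-c1cc3ccccc3o1)cn2[C@@H]1O[C@H](CO)[C@@H](O)[C@H]1O` gives 14500 nM, a gap well beyond the scatter. Compound 2 `CSc1ncnc2c1c(-c1ccsc1)cn2[C@@H]1O[C@H](CO)[C@@H](O)[C@H]1O` reaches only a limit of the assay, > 20000 nM.

The next compound, compound 4 `C#Cc1cn([C@@H]2O[C@H](CO)[C@@H](O)[C@H]2O)c2ncnc(NC)c12`, keeps the ethynyl group of compound 3 and changes one other group: methylamino in place of methylsulfanyl on an aromatic carbon. Methylamino takes the place of methylsulfanyl on an aromatic carbon, next to the ring nitrogen.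

Going by the values given here, only one step has been measured between compounds that differ in one place. Putting ethynyl in place of thiophen-3-yl on an aromatic carbon gives an at least 220-fold lower number from compound 2 to compound 3 (2.34 log units; beyond the scatter). That large step concerns a different group, so it does not give the size of this swap directly, but it does show that one swap on the shared core can move the number far. A wide range is therefore warranted.

Among the compounds with values here, because compound 3 sits at 90 nM, the lowest number so far, the expected direction is toward a higher number in this assay. The estimated change is a 3.3-fold higher number from compound 3 to compound 4 (0.52 log units; beyond the scatter). For compound 4 the expected value is 300 nM, with an estimated range from 40 nM to 3000 nM.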

Compound 4, half-maximal inhibitory concentration: > 20000 nM
Compound 4: only a limit was reported; the forecaster's own chance of this, stated with the estimate: 8%; middle value at least 66-fold (1.82 log units) from the limit.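

In this assay, the group next to the ring nitrogen proves to matter as well: with the ethynyl group kept, methylamino in place of methylsulfanyl gives an at least 220-fold higher number from compound 3 to compound 4 (2.34 log units; beyond the scatter). The two groups have the same count of heavy atoms and differ in one atom, and methylamino brings a hydrogen-bond donor that methylsulfanyl lacks, so even a swap this small can move the number far on the shared core. Compound 4 gives > 20000 nM, which is a limit of the assay and not a number, and the full size of the step cannot be read because it rests on that limit: the limit of > 20000 nM in this assay, at which 2 of the 4 values shown sit.

The compounds shown do not separate the loss of sulfur from the gain of the donor. From the compounds shown here alone, whether ethylsulfanyl or dimethylamino at this place would keep a number close to that of compound 3 also stays open.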